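From 1-phenylethyl to 4-acetamidobenzyl on a shared core

This account rests on a few compounds, and the source may have more. Where it says the series, first, only, none or still open, it means among the compounds named here.

- Compound 1 `CCCCCCCCCCCCCCCCNC(=O)[C@@H]1CSC(Cc2ccccc2)N1`: 6500 nM
- Compound 2 `CCCCCCCCCCCCCCCCNC(=O)[C@@H]1CSC(C(C)c2ccccc2)N1`: 12200 nM

In a functional assay on B16-F1 cells (Mus musculus) for antiproliferative activity, read by sulforhodamine B assay, with a stated time of 48 h (a lower number here means a stronger inhibitor, a higher number a weaker inhibitor), compound 2 gives 12200 nM, a number within the scatter of compound 1 at 6500 nM. Compound 3 `CCCCCCCCCCCCCCCCNC(=O)[C@@H]1CSC(Cc2ccc(NC(C)=O)cc2)N1` has 4-acetamidobenzyl in place of 1-phenylethyl on a saturated ring carbon. Going by the values given here, the one measured step, a 1.9-fold higher number from compound 1 to compound 2 (0.27 log units; within the scatter), adds a methyl in place of hydrogen on the saturated chain carbon and stays within the scatter. Among the compounds with values here, no measured compound carries 4-acetamidobenzyl, so the data give no size for that change, and no step beyond the scatter is expected in this assay. The expected change is a 1.7-fold lower number from compound 2 to compound 3 (0.24 log units; within the scatter). Compound 3 is estimated at 7000 nM, with an expected range of 2800 nM to 16000 nM.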

Compound 3, half-maximal inhibitory concentration: 171000 nM
Compound 3: the middle estimate sits 24-fold (1.39 log units) below what was measured; measured number above the stated range.
By their numbers in this assay, from the lowest: compounds 1 and 2 (each within the scatter of the next); then compound 3.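

In this assay, the group on this saturated ring carbon turns out to matter far more than the methyl step suggested: acetamido in place of hydrogen on an aromatic carbon brings a 26-fold higher number from compound 1 to compound 3 (1.42 log units; beyond the scatter), and 4-acetamidobenzyl in place of 1-phenylethyl brings a 14-fold higher number from compound 2 to compound 3 (1.15 log units; beyond the scatter). A change on the aromatic ring can therefore cost much antiproliferative activity here. Nothing available explains this loss.

The compounds shown leave open whether an amine or a carboxylic acid on that aromatic carbon would bring a similar loss, or whether it is particular to acetamido.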